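Hydroxy to 4-carbamoylphenyl on the amide-type nitrogen

The compounds below may be only part of what the source reports. "The series", "measured", "known", "first", "only" and "open" are said of these compounds alone.

In a functional assay on CLL cells (Homo sapiens) for cytotoxicity, read by MTT assay, with a stated time of 48 h (on this read-out lower numbers stand for an effect already at smaller amounts and higher numbers for an effect only at larger amounts of compound), compound 3 (`C=C(CC)C(=O)c1ccc(OCC(=O)NO)c(Cl)c1Cl`) gives 4500 nM. Compound 2 (`C=C(CC)C(=O)c1ccc(OCC(=O)Nc2ccc(/C=C/C(=O)O)cc2)c(Cl)c1Cl`) gives 3000 nM, within the scatter of compound 3, while compound 1 (`C=C(CC)C(=O)c1ccc(OCC(=O)NCCCN2CCCC2=O)c(Cl)c1Cl`) gives 13800 nM. Compound 4 (`C=C(CC)C(=O)c1ccc(OCC(=O)Nc2ccc(C(N)=O)cc2)c(Cl)c1Cl`) carries 4-carbamoylphenyl in place of hydroxy on an amide-type nitrogen. For the measured compounds named here, the only measured step at that nitrogen, a 3.1-fold lower number from compound 1 to compound 3 (0.49 log units; beyond the scatter), was modest and involved a different group, so it bears on this change only indirectly. Compound 2 also has a six-membered aromatic ring on that nitrogen and gives 3000 nM, so no step beyond the scatter is expected in this assay. The expected step is a 1.1-fold lower number from compound 3 to compound 4 (0.05 log units; within the scatter). For compound 4 the estimated value is 4000 nM, with an expected range of 1500 nM to 11000 nM.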

Compound 4, half-maximal effective concentration: 3700 nM
Compound 4: the middle estimate sits 1.1-fold (0.03 log units) above what was measured; low and high end bracket the measured number.
By their numbers in this assay, from the lowest: compounds 2, 4 and 3 (each within the scatter of the next); then compound 1.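

In this assay, the much larger 4-carbamoylphenyl, with its six-membered aromatic ring, can replace hydroxy on the amide-type nitrogen without a change beyond the scatter (a 1.2-fold lower number from compound 3 to compound 4 (0.09 log units; within the scatter)). Carbamoyl in place of 2-carboxyethenyl on the aromatic carbon also stays within the scatter (a 1.2-fold higher number from compound 2 to compound 4 (0.09 log units; within the scatter)), whereas replacing 3-(2-oxopyrrolidin-1-yl)propyl with 4-carbamoylphenyl gives a modest step beyond it (a 3.7-fold lower number from compound 1 to compound 4 (0.57 log units; beyond the scatter)). No measured evidence explains these results. The compounds shown leave open how an amine or a carboxylic acid directly on that aromatic ring would compare. They also leave open whether a longer chain between the amide-type nitrogen and the ring would keep the number in this range.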